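Compound 3 to compound 4: swapping one amine for another

The source may report more compounds than this note shows. Statements on the series, on what has been measured and on what is new or still open speak of the compounds shown alone.

Values in a functional assay on A549 cells (Homo sapiens) for cytotoxicity, read by MTT assay, with a stated time of 48 h (a lower number here means a stronger inhibitor, a higher number a weaker inhibitor), for the measured compounds:
Compound 1 `COc1c(OCCCCN2CCNCC2)cc(O)c2c(=O)cc(-c3ccccc3)oc12` gives 1740 nM
Compound 2 `COc1c(OCCCN2CCN(C)CC2)cc(O)c2c(=O)cc(-c3ccccc3)oc12` gives 9900 nM
Compound 3 `CCN(CC)CCCOc1cc(O)c2c(=O)cc(-c3ccccc3)oc2c1OC` gives 1830 nM

Compound 3 shares the low end of these numbers: a 1.1-fold higher number from compound 1 to compound 3 (0.02 log units; within the scatter) lies within the scatter, whereas a 5.4-fold lower number from compound 2 to compound 3 (0.73 log units; beyond the scatter) lies beyond it. Within the data shown here, compound 4 `COc1c(OCCCN2CCCC2)cc(O)c2c(=O)cc(-c3ccccc3)oc12` carries pyrrolidin-1-yl in place of diethylamino on a saturated chain carbon, three bonds along the chain from an oxygen on an aromatic ring and no measured step covers this exact swap. Other changes of the amine group ranged from a 1.1-fold higher number from compound 1 to compound 3 (0.02 log units; within the scatter) to a 5.7-fold higher number from compound 1 to compound 2 (0.76 log units; beyond the scatter) so a step within the scatter in this assay is expected, though a modest one remains possible. The expected step is a 1.2-fold higher number from compound 3 to compound 4 (0.08 log units; within the scatter) in this estimate. In this assay compound 4 is estimated at 2200 nM with an expected range from 800 nM to 6500 nM.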

Compound 4, half-maximal inhibitory concentration: 1390 nM
Compound 4: middle estimate off by 1.6-fold (0.20 log units), on the high side; the measured number falls inside the stated range.
By their numbers in this assay, from the lowest: compounds 4, 1 and 3 (each within the scatter of the next); then compound 2.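

Tying diethylamino into the pyrrolidin-1-yl ring, with the same heavy atoms, leaves the number within the scatter in this assay (a 1.3-fold lower number from compound 3 to compound 4 (0.12 log units; within the scatter)), and the same holds against the piperazine of the longer chain (a 1.3-fold lower number from compound 1 to compound 4 (0.10 log units; within the scatter)). A ring at this place therefore does not by itself bring the weak number of compound 2, which stands clearly apart (a 7.1-fold lower number from compound 2 to compound 4 (0.85 log units; beyond the scatter)). No supporting evidence bears on why these amines group this way. From the compounds shown here alone, it remains open whether piperidin-1-yl or morpholin-4-yl on the same propyl chain would fall with compound 4 or with compound 2.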